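The source may report more compounds than this note shows. Statements on the series, on what has been measured and on what is new or still open speak of the compounds shown alone.

Measured compounds so far:

Compound 1, `CCOC(=O)c1c(-c2cccc(Oc3ccccc3)c2)[nH]c2cc(OC)ccc2c1=O`: in an ADME assay on HepG2 cells (Homo sapiens) for cytotoxicity, read by luminescence, with a stated time of 72 h (on this read-out lower numbers stand for an effect already at smaller amounts and higher numbers for an effect only at larger amounts of compound), compound 1 gives > 21500 nM, which is a limit of the assay and not a number.
Compound 2, `CCOC(=O)c1c(-c2cccc(Cl)c2)[nH]c2cc(OC)ccc2c1=O`: compound 2 gives > 21500 nM, likewise a limit of the assay.
Compound 3, `CCOC(=O)c1c(-c2cccc(Oc3ccccc3)c2)[nH]c2cc(OC)c(Cl)cc2c1=O`: compound 3 gives > 21500 nM, again a limit of the assay.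

Compound 2 differs from compound 1 by chloro in place of phenoxy on an aromatic carbon, and the step that the two limits leave unreadable from compound 1 to compound 2 cannot be read, since both values are limits. The two cores differ as chloro in place of hydrogen on an aromatic carbon, and the step that the two limits leave unreadable from compound 1 to compound 3 is likewise unreadable for the same reason. Compound 4, `CCOC(=O)c1c(-c2cccc(Cl)c2)[nH]c2cc(OC)c(Cl)cc2c1=O`, has not yet been measured in this assay. It differs from compound 3 by chloro in place of phenoxy on an aromatic carbon, which is the same change as from compound 1 to compound 2, at the same kind of place. Because every value shown sits at the limit of > 21500 nM in this assay, at which 3 of the 3 values shown sit, the step from compound 3 to compound 4 is expected to be a step that the limit leaves unreadable from compound 3 to compound 4, a step that again will most likely not be readable. Compound 4 is therefore expected to give 35000 nM, with the expected range running from 15000 nM to 100000 nM, most probably reported only as a limit.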

Compound 4, half-maximal effective concentration: > 21500 nM
Compound 4 gave a limit, no number (the forecaster's own chance of this, stated with the estimate: 85%); the middle value lies beyond the limit too.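

In this assay compound 4 gives > 21500 nM as a limit and not a number. Among the compounds shown here, neither the step from compound 3 to compound 4 nor the one from compound 2 to compound 4 can be read, as all values shown are limits: the limit of > 21500 nM in this assay, at which 4 of the 4 values shown sit. The compounds shown leave open at what concentration any of the four would show an effect, and whether exchanging phenoxy for chloro changes it.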